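This account rests on a few compounds, and the source may have more. Where it says the series, first, only, none or still open, it means among the compounds named here.

Measured so far:
compound 1 `O=C(O)Cc1sc(C(c2ccc(F)cc2)c2ccc(F)cc2)nc1-c1ccc(Cl)cc1`: 9.7 nM
compound 2 `O=C(O)Cc1sc(C(c2ccc(F)cc2)c2ccc(F)cc2)nc1-c1ccnc(Cl)c1`: 3.1 nM

In an in vitro assay on HEK385-7 cells for displacement of a labelled ligand from prostaglandin D2 receptor 2 (Homo sapiens) (a higher number here means a weaker inhibitor, a lower number a stronger inhibitor), compound 2 gives the lowest of the two numbers; the nearest is compound 1, and the gap is a 3.1-fold lower number from compound 1 to compound 2 (0.50 log units; beyond the scatter). Compound 3 `CN(C)c1cc(-c2nc(C(c3ccc(F)cc3)c3ccc(F)cc3)sc2CC(=O)O)ccn1` differs from compound 2 by dimethylamino in place of chloro on an aromatic carbon. For the measured compounds named here, no measured step bears directly on this change; the only step, a 3.1-fold lower number from compound 1 to compound 2 (0.50 log units; beyond the scatter), concerns a different exchange. The expected step is therefore a 1.3-fold higher number from compound 2 to compound 3 (0.11 log units; within the scatter), no change beyond the scatter. The estimate for compound 3 is 4 nM, in the range 1.5 nM to 12 nM.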

Compound 3, half-maximal inhibitory concentration: 380 nM
For compound 3 the middle estimate is 95-fold (1.98 log units) below the measured one; measured number outside the range, above it.
By their numbers in this assay, from the lowest: compound 2; then compound 1; then compound 3.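

At the place next to the ring nitrogen, the exchange is far from neutral: in this assay dimethylamino in place of chloro gives a 120-fold higher number from compound 2 to compound 3 (2.09 log units; beyond the scatter). The result also falls well behind the 4-chlorophenyl compound, with a 39-fold higher number from compound 1 to compound 3 (1.59 log units; beyond the scatter), so the gain seen with 2-chloropyridin-4-yl does not survive this exchange. No evidence is available to explain the loss.

On these data alone, whether a smaller amine such as methylamino, or a methoxy group, would behave like chloro or like dimethylamino remains open. So does whether any group at this place can improve on chloro.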